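This account rests on a few compounds, and the source may have more. Where it says the series, first, only, none or still open, it means among the compounds named here.

In a functional assay on EBC-1 cells (Homo sapiens) for antiproliferative activity, with a stated time of 72 h (a lower number here means a stronger inhibitor, a higher number a weaker inhibitor), the record is short. Compound 1 `Cn1cc(-c2cn3c(Cc4ccc5ncccc5c4)cnc3cc2C#N)cn1` has the entry "not determined" (no result reported) and so offers nothing to compare. Compound 2 `CNC(=O)c1cc(-c2cc(F)c3ncc(Cc4ccc5ncccc5c4)n3c2)ccc1Cl` gives 946 nM and compound 3 `O=C(c1ccc(-c2cc(F)c3ncc(Cc4ccc5ncccc5c4)n3c2)cc1F)N1CCC2(COC2)C1` gives 406 nM as the lower of the two numbers, a gap that lies beyond the usual scatter of repeated measurements.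

Compound 4 `O=C(NC1CCOCC1)c1ccc(-c2cc(F)c3ncc(Cc4ccc5ncccc5c4)n3c2)cc1F` has yet to be measured. The change from compound 3 is a group of 7 heavy atoms (5 carbon, 1 nitrogen, 1 oxygen; one six-membered non-aromatic ring with 1 hetero atom) in place of a group of 8 heavy atoms (6 carbon, 1 nitrogen, 1 oxygen; one four-membered non-aromatic ring with 1 hetero atom, one five-membered non-aromatic ring with 1 hetero atom), on a carbonyl carbon and the rest of the structure stays the same. The entering group is (oxan-4-yl)amino, and it sits on a carbonyl carbon, as the group it replaces did.

Going by the values given here, no measured pair of compounds isolates this kind of swap, so any expectation here is loose. Compound 2 at 946 nM also carries an amide hydrogen, but it differs from compound 4 in other places too and is only a weak guide. A small shift towards weaker inhibition in this assay is expected, an estimated 1.4-fold higher number from compound 3 to compound 4 (0.13 log units; within the scatter) that may well stay within the scatter. For compound 4 the estimated value is 550 nM with an expected range from 180 nM to 1600 nM in this measurement.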

Compound 4, half-maximal inhibitory concentration: 70.5 nM
For compound 4 the middle estimate is 7.8-fold (0.89 log units) above the measured one, outside the stated range (below it).
By their numbers in this assay, from the lowest: compound 4; then compound 3; then compound 2.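

Putting (oxan-4-yl)amino on the carbonyl carbon, in place of the group with a four-membered and a five-membered non-aromatic ring, gives a 5.8-fold lower number from compound 3 to compound 4 (0.76 log units; beyond the scatter) in this assay. Going by these compounds alone, this is the first comparison here in which only one place changes, and it shows that the group on this carbonyl carbon can move the antiproliferative result by more than the usual scatter. The swap alters several things at once, bringing in the amide hydrogen and a single six-membered ring with its oxygen, and no measurement at hand explains why the number falls.

The compounds shown leave open whether the amide hydrogen, the ring size or the ring oxygen accounts for the step, since all three change together between these two structures. A cyclohexylamino group on the same carbonyl carbon would test the ring oxygen, while an oxan-4-yl amide carrying a methyl group on its nitrogen would test the amide hydrogen.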